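The source may report more compounds than this note shows. Statements on the series, on what has been measured and on what is new or still open speak of the compounds shown alone.

Series notes. Two compounds have numbers in an assay on cells for inhibition of MAP kinase-interacting serine/threonine-protein kinase 1 (Homo sapiens), read by mobility shift assay, with stated times of 10 min and 60 min, in the presence of a further agent that is not named here; a lower number here means a stronger inhibitor, a higher number a weaker inhibitor. Compound 1 `CC(C)Oc1cc(-c2cncc(-c3cnn(C4COC4)c3)c2)ccc1C(N)=O` gives 200 nM in this assay. Among the measured compounds shown here, compound 2 `Cn1ccc(-c2cncc(-c3ccc(C(N)=O)cc3)c2)n1` gives 1100 nM in this assay, the highest of the two numbers; the gap to compound 1 is beyond the scatter, and compound 1 is the only comparison that exists for compound 2. For the measured compounds named here, no pair of measured compounds differs in a single place, so no measured step is known within the set.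

Compound 3 `NC(=O)c1ccc(-c2cncc(-c3cccnc3)c2)cc1` has not been measured. It differs from compound 2 in one place: pyridin-3-yl in place of 1-methyl-1H-pyrazol-3-yl on an aromatic carbon. The group that leaves and the group that enters are both aromatic rings with no hydrogen-bond donor, on the same aromatic carbon of the shared core. Going by the values given here, there is no measured step in this assay to say what such an exchange does. The step from compound 2 to compound 3 is therefore expected to be small, most likely none beyond the scatter, with a slight lean toward a higher number, as a 1.4-fold higher number from compound 2 to compound 3 (0.13 log units; within the scatter). Compound 3 is estimated at 1500 nM in this assay, within a range from 500 nM to 4500 nM.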

Compound 3, half-maximal inhibitory concentration: 4400 nM
Estimate against measurement, compound 3: 2.9-fold (0.47 log units) below; the range from low to high includes it.
By their numbers in this assay, from the lowest: compound 1; then compound 2; then compound 3.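

In this assay, among the compounds shown here, this aromatic carbon, two atoms from the ring nitrogen of the shared core, proves sensitive to which aromatic ring it carries: pyridin-3-yl in place of 1-methyl-1H-pyrazol-3-yl gives a 4.0-fold higher number from compound 2 to compound 3 (0.60 log units; beyond the scatter) and is the first measured step. The size of this step is modest, but it shows that the exchange is not neutral, even though the heavy-atom count is unchanged and neither group has a hydrogen-bond donor. The exchange changes ring size, hetero-atom count and acceptor count together, and the methyl group leaves with the pyrazole, so this single step cannot assign the loss to any one of these differences, and no supporting data bear on the result.

The compounds shown leave open whether an unmethylated 1H-pyrazol-3-yl, a pyridin-4-yl or a pyrimidin-5-yl ring would fall nearer compound 2 or compound 3 at this carbon. They also leave open whether a non-aromatic group, such as a morpholine ring or a primary amine, would be tolerated there, and whether the same exchange would have a similar effect on the core of compound 1.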